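Swapping a Propyl Chain for an Aminophenyl Ring

The source may report more compounds than this note shows. Statements on the series, on what has been measured and on what is new or still open speak of the compounds shown alone.

Within the data shown here, compound 1 `CCCC(=O)Nc1cccc(NC(=O)COc2ccc3c(=O)ccoc3c2)c1` gives 1430 nM in an assay on isolated protein for inhibition of Rho-associated protein kinase 1 (Homo sapiens), read by scintillation counting, radiometric assay and 33P incorporation, with a stated time of 40 min, in the presence of a further agent that is not named here (on this read-out higher numbers stand for weaker inhibition and lower numbers for stronger inhibition), the highest of the three numbers measured so far and therefore the weakest inhibition among them. Two measured neighbours share its core and differ only in the group on the carbonyl carbon. Compound 2 `CCCc1ccc(C(=O)Nc2cccc(NC(=O)COc3ccc4c(=O)ccoc4c3)c2)cc1` gives 143 nM. That step is a 10-fold lower number from compound 1 to compound 2 (1.00 log units; beyond the scatter). Compound 3 `CC(C)(C)c1cc(C(=O)Nc2cccc(NC(=O)COc3ccc4c(=O)ccoc4c3)c2)no1` gives 101 nM. That step is a 14-fold lower number from compound 1 to compound 3 (1.15 log units; beyond the scatter). Between the two ring-bearing compounds the difference, a 1.4-fold lower number from compound 2 to compound 3 (0.15 log units; within the scatter), lies within the scatter. Compound 4 `Nc1cccc(C(=O)Nc2cccc(NC(=O)COc3ccc4c(=O)ccoc4c3)c2)c1` has not yet been measured. It differs from compound 1 in one place: 3-aminophenyl in place of propyl on a carbonyl carbon. Among the measured compounds shown here, both measured steps away from compound 1 replaced the propyl chain with a ring and lowered the number clearly, and the new group is again a ring, so a drop of comparable size is expected, although the amino substituent has no counterpart among the measured compounds. The estimate for compound 4 is a step of a 9.5-fold lower number from compound 1 to compound 4 (0.98 log units; beyond the scatter), giving an expected 150 nM with a range from 50 nM to 500 nM.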

Compound 4, half-maximal inhibitory concentration: 670 nM
The estimate for compound 4 lay 4.5-fold (0.65 log units) below the measured number; measured number above the stated range.
By their numbers in this assay, from the lowest: compounds 3 and 2 (each within the scatter of the next); then compound 4; then compound 1.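

A ring on this carbonyl carbon does not by itself bring the full drop: 3-aminophenyl in place of propyl gives only a 2.1-fold lower number from compound 1 to compound 4 (0.33 log units; beyond the scatter) in this assay and so falls well short of the steps seen with the two earlier ring groups. The ring-bearing compounds, which had been within the scatter of each other, now separate, with a 4.7-fold higher number from compound 2 to compound 4 (0.67 log units; beyond the scatter) and a 6.6-fold higher number from compound 3 to compound 4 (0.82 log units; beyond the scatter) showing that the identity of the ring group matters at this position, not just the presence of a ring. Nothing available here explains this shortfall. From the compounds shown here alone, what remains open is whether the amine or the phenyl ring accounts for the weaker result, which a plain phenyl group without the amine could help to separate. Going by these compounds, how a longer chain in place of propyl would compare also remains open.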